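An Amino Group Added to Compound 1

The source may hold more compounds than are shown below. What is called first, only, known or untested is meant among the compounds shown, and "the series" means these compounds.

Compound 1 (`CCn1cc(-c2nc3ccccc3[nH]2)c(=O)c2cc(F)c(N3CCNCC3)nc21`) is the starting point. In a functional assay on U-937 cells (Homo sapiens) for cytotoxicity, read by sulforhodamine B assay, with a stated time of 48 h (a lower number here means a stronger inhibitor, a higher number a weaker inhibitor), compound 1 gives > 10000 nM as a limit of the assay and not a number. In this assay, going by the values given here, compound 2 (`CCn1cc(-c2nc3ccc(Cl)cc3[nH]2)c(=O)c2cc(F)c(N3CCNCC3)cc21`) gives 4200 nM as the only true number so far. Compound 3 (`CCn1cc(-c2nc3ccc(N)cc3[nH]2)c(=O)c2cc(F)c(N3CCNCC3)nc21`) differs from compound 1 in one place, with amino in place of hydrogen on an aromatic carbon of a six-membered aromatic ring of carbon only. Among the compounds with values here, no measured pair shows this change alone, so any forecast is loose. Within the data shown here, compound 2 with 4200 nM as its reading is the only guide to what a measurable result looks like here. A small gain in strength is expected (an at least 1.2-fold lower number from compound 1 to compound 3 (0.09 log units; that floor lies within the scatter)) in this assay and the reading may well stay at the limit. Compound 3 is estimated at 8000 nM with an expected range from 2500 nM to 25000 nM for this measurement.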

Compound 3, half-maximal inhibitory concentration: > 10000 nM
Compound 3: a limit, no number (the forecaster's own chance of this, stated with the estimate: 50%); middle value at least 1.2-fold (0.09 log units) from the limit.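

Compound 1 and compound 3 both stop at a limit of the assay and give no number, so no step between them can be read: the limit of > 10000 nM in this assay, at which 2 of the 3 values shown sit.

The compounds shown leave open whether amino in place of hydrogen on an aromatic carbon changes strength in this assay at all, and by how much.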